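The source may report more compounds than this note shows. Statements on the series, on what has been measured and on what is new or still open speak of the compounds shown alone.

Measured so far:
- compound 1, `COc1cc(C)cc(-c2c(-c3ccnc(-c4ccc(N(C)C)cc4)c3)cnn2CC#N)c1`: 19%
- compound 2, `Cc1cc(O)cc(-c2nn(CC#N)cc2-c2ccnc(-c3ccc(N(C)C)cc3)c2)c1`: 18%

Both numbers come from a functional assay on ACHN cells (Homo sapiens) for cytotoxicity, read by sulforhodamine B assay, with a stated time of 48 h, tested at 1 uM; a lower number here means a stronger effect, a higher number a weaker effect of the compound at the concentration tested. Going by the values given here, compound 1 stands next to compound 2 with a gap that lies within the usual scatter, so the two read as one level; no ordering of the pair is supported, and no single-change step has been characterised so far.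

Compound 3, `COc1cc(C)cc(-c2c(-c3ccnc(-c4ccc(C(C)=O)cc4)c3)cnn2CC#N)c1`, is not yet measured. Against compound 1 the change is acetyl in place of dimethylamino on an aromatic carbon. The two measured compounds give no guide to a change of this kind, so the size and direction of the step cannot be anchored on a shown value. The working expectation is a step of a number 9 percentage points higher from compound 1 to compound 3 (within the scatter) that is modest and slightly toward a weaker effect, but it may just as well fall within the scatter. On that basis compound 3 is estimated at 28%, with a range from 12% to 55%.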

Compound 3, a percentage reported as activity, at one concentration (the size of the read-out at that concentration, not a potency): 21%
Estimate against measurement, compound 3: 7 percentage points above; the range from low to high includes it.
By their numbers in this assay, from the lowest: compounds 2, 1 and 3 (each within the scatter of the next).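

In this assay the exchange of dimethylamino for acetyl on an aromatic carbon, para to a large group, gives a number 2 percentage points higher from compound 1 to compound 3 (within the scatter). Going by these compounds alone, this is the first single-change step, and it shows that the two groups read as one level at this position, at the one concentration tested, even though the nitrogen-bearing substituent gives way to a carbonyl-bearing one of the same heavy-atom count. No measurement on hand speaks to why the level holds across this change.

Still open, from the compounds shown here alone, is whether this tolerance extends to other kinds of group at the same position, such as a carboxylic acid, a primary amine or a longer alkyl chain. A single concentration also leaves any potency difference between these compounds unresolved.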